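The compounds below may be only part of what the source reports. "The series", "measured", "known", "first", "only" and "open" are said of these compounds alone.

Measured so far in a functional assay on HEK293 cells for antagonist activity at Oxytocin receptor (Homo sapiens), read by calcium flux, with a stated time of 10 min, in the presence of a further agent that is not named here; a higher number here means a weaker inhibitor, a lower number a stronger inhibitor:
compound 1 `CCOCc1nnc(N2C[C@@H]3C[C@]3(c3ccc(F)cc3Cl)C2)n1-c1ccc(OC)nc1` gives 9.3 nM;
compound 2 `COc1ccc(-n2c(CO[C@H]3CCOC3)nnc2N2C[C@@H]3C[C@]3(c3ccc(F)cc3Cl)C2)cn1` gives 184 nM;
compound 3 `COc1ccc(-n2c(C(F)F)nnc2N2C[C@@H]3C[C@]3(c3ccc(F)cc3Cl)C2)cn1` gives 52 nM.

Compound 3 stands second highest of the three numbers: the step of a 5.6-fold higher number from compound 1 to compound 3 (0.75 log units; beyond the scatter) was modest, and the step of a 3.5-fold lower number from compound 2 to compound 3 (0.55 log units; beyond the scatter) was modest in the other direction. Compound 4 `COc1ccc(-n2c(C3CC3)nnc2N2C[C@@H]3C[C@]3(c3ccc(F)cc3Cl)C2)cn1` differs from compound 3 by cyclopropyl in place of difluoromethyl on an aromatic carbon. Both measured steps that changed the group on this aromatic carbon, a 5.6-fold higher number from compound 1 to compound 3 (0.75 log units; beyond the scatter) and a 3.5-fold lower number from compound 2 to compound 3 (0.55 log units; beyond the scatter), bear on the change, and the largest swing seen, a 20-fold higher number from compound 1 to compound 2 (1.30 log units; beyond the scatter), also came from that position. Among the measured compounds shown here, no measured step exchanges difluoromethyl for cyclopropyl, so the direction is open. Compound 4 is therefore expected to sit close to its parent, an estimated step of a 1.3-fold lower number from compound 3 to compound 4 (0.11 log units; within the scatter). Compound 4 is estimated at 40 nM, within the range 12 nM to 130 nM.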

Compound 4, half-maximal inhibitory concentration: 433 nM
Compound 4: the middle estimate sits 11-fold (1.03 log units) below what was measured; the whole stated range lies below it.
By their numbers in this assay, from the lowest: compound 1; then compound 3; then compound 2; then compound 4.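

At the aromatic carbon between two ring nitrogen atoms, cyclopropyl gives the weakest inhibitor of the four in this assay, with an 8.3-fold higher number from compound 3 to compound 4 (0.92 log units; beyond the scatter), a 2.4-fold higher number from compound 2 to compound 4 (0.37 log units; beyond the scatter) and a 47-fold higher number from compound 1 to compound 4 (1.67 log units; beyond the scatter), the widest swing yet at this position. Difluoromethyl and cyclopropyl each have 3 heavy atoms and no hydrogen-bond donors or acceptors, so these matching counts do not keep the numbers together. Nothing available explains the loss.

As far as these compounds go, whether a methyl, a trifluoromethyl or an amine on this carbon would sit nearer compound 1 or compound 4 remains open. A propyl chain would test whether the ether oxygen of the ethoxymethyl group in compound 1 matters, or only its length.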